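A few compounds are considered here, and "the series" means these few. Any claim that something is new, unique, unknown or untested is made for them only; others in the source may bear on it.

In a functional assay on DU-145 cells (Homo sapiens) for inhibition, read by trypan blue exclusion, with a stated time of 96 h (on this read-out lower numbers stand for stronger inhibition of growth and higher numbers for weaker inhibition of growth), the two measured compounds are:
compound 1, `Cc1ccc(CS(=O)(=O)/C(=C/c2c[nH]c3ccc(Br)cc23)C(=O)c2ccc(Cl)cc2)cc1`: 10000 nM
compound 2, `O=C(/C(=C\c1ccccc1O)Sc1ccccc1Br)c1ccc(Br)cc1`: 50000 nM

Compound 1 holds the lowest of the two numbers; the value of compound 2 lies beyond the usual scatter from it, but the two structures differ in several places at once. Compound 3, `COc1ccccc1/C=C(\C(=O)c1ccc(Cl)cc1)S(=O)(=O)Cc1ccc(C)cc1`, is still unmeasured. It differs from compound 1 in one place: 2-methoxyphenyl in place of 5-bromo-1H-indol-3-yl on a double-bonded chain carbon bound to a double-bonded chain carbon. Among the compounds with values here, no measured pair shows this exact change, so the direction rests on judgment alone. For compound 3 a modest weakening is expected, a 2.0-fold higher number from compound 1 to compound 3 (0.30 log units; within the scatter). The estimated value of compound 3 in this assay is 20000 nM, with a range from 7000 nM to 60000 nM.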

Compound 3, concentration for 50% growth inhibition: 10000 nM
For compound 3 the middle estimate is 2.0-fold (0.30 log units) above the measured one; the measured number falls inside the stated range.
By their numbers in this assay, from the lowest: compounds 1 and 3 (each within the scatter of the next); then compound 2.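

In this assay, 2-methoxyphenyl in place of 5-bromo-1H-indol-3-yl gives no change at the digits printed from compound 1 to compound 3 (within the scatter), so growth inhibition at this place does not depend on the group that leaves. The group that enters has one ring rather than two, no bromine and no hydrogen-bond donor, so this pair needs none of these three features to keep its number. No measurement here explains why the two groups read alike. As far as these compounds go, it remains open whether a plain phenyl or a pyridine ring would read the same, and whether any group at this place can give a clearly lower number.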